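This account rests on a few compounds, and the source may have more. Where it says the series, first, only, none or still open, it means among the compounds named here.

Among the compounds with values here, in an in vivo ADME assay on the whole organism for pharmacokinetics, with Rattus norvegicus as the target, at a dose of 2 mg/kg by the oral route (on this read-out higher numbers stand for higher oral bioavailability and lower numbers for lower oral bioavailability), compound 1 `COc1ccc2c(c1)CC(c1nc3ccc(-c4ccnc(N)n4)cc3[nH]1)CO2` gives 35% as the only true number so far. Compound 2 `Nc1nccc(-c2ccc3nc(C4COc5c(cccc5C(=O)NC5CC5)C4)[nH]c3c2)n1` reads < 1% in the same test, and this is a limit of the assay, not a number. Compound 1 therefore stands well clear of that limit, with room to fall.

Compound 3 `CN(C)CCCNC(=O)c1ccc2c(c1)CC(c1nc3ccc(-c4ccnc(N)n4)cc3[nH]1)CO2` keeps the core of compound 1 and differs in one place, with (3-(dimethylamino)propyl)carbamoyl in place of methoxy on an aromatic carbon as the counted change. In words, (3-(dimethylamino)propyl)carbamoyl takes the place of methoxy on an aromatic carbon, so a much larger group now sits on the six-membered aromatic ring of carbon only.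

Within the data shown here, no measured pair shows what a change of this kind does, so the size of the step has to be judged. The expectation of a fall rests on that larger group and on compound 2, whose < 1% is a limit. A drop beyond the usual scatter is expected, with a number 29 percentage points lower from compound 1 to compound 3 (beyond the scatter) as the estimated step. For compound 3 the estimated value is 6% in this assay, with 1% to 22% as the expected range.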

Compound 3, oral bioavailability: < 1%
Compound 3 ended at the assay's limit; the forecaster's own chance of this, stated with the estimate: 25%; middle value at least 5 percentage points away from the limit.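

Within the data shown here, this is the first measured pair that differs in one place only, and it shows that this position on the six-membered aromatic ring of carbon only does not tolerate every group. In this assay, putting (3-(dimethylamino)propyl)carbamoyl in place of methoxy gives a number at least 34 percentage points lower from compound 1 to compound 3 (beyond the scatter) and so removes the measurable oral bioavailability seen for the core of compound 1. The reading for compound 3 is a limit of the assay and not a number, so the step can be stated only as a bound, because the true value cannot be read at this limit: the limit of < 1% in this assay, at which 2 of the 3 values shown sit.

The compounds shown cannot tell whether the fall comes from the carbonyl and amide hydrogen attached to the ring, from the length of the propyl chain, or from the dimethylamino group at its end. A plain primary amide, a shorter chain ending in the same amine, or a carboxylic acid at this place would help to separate these parts, and the values shown cannot say how any of them would behave.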